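Aromatic ring in place of a saturated chain at the shared core

The compounds below may be only part of what the source reports. "The series", "measured", "known", "first", "only" and "open" are said of these compounds alone.

Measured so far in a functional assay on the whole organism (strain C57B/6) with Mus musculus as the target, in the maximal electroshock model; on this read-out lower numbers stand for an effect already at smaller amounts and higher numbers for an effect only at larger amounts of compound:
compound 1 `CCCCCCOc1ccc(-n2cnnc2CCCCC)cc1`: 32.8 mg/kg
compound 2 `CCCCCCOc1ccc(-n2cnnc2-c2ccc(C)cc2)cc1`: 11.4 mg/kg

Compound 1 stands at the highest of the two numbers in this assay; its nearest neighbour is compound 2, reached by the step of a 2.9-fold lower number from compound 1 to compound 2 (0.46 log units; beyond the scatter), which came with 4-methylphenyl in place of pentyl on an aromatic carbon.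

Compound 3 `CCCCCCOc1ccc(-n2cnnc2Cc2ccccc2)cc1` is not yet measured. It differs from compound 1 by phenyl in place of butyl on a saturated chain carbon bound to an aromatic carbon. Within the data shown here, the single measured step that bears on this change is a 2.9-fold lower number from compound 1 to compound 2 (0.46 log units; beyond the scatter), where an aromatic ring likewise replaced a saturated chain. Here the ring enters one bond further out, so a lowering of the number is expected, but a smaller one than that step, and possibly no more than the scatter.

For compound 3 the expected value in this assay is 18 mg/kg, in the range 8 mg/kg to 40 mg/kg. This estimate means an expected step of a 1.8-fold lower number from compound 1 to compound 3 (0.26 log units; within the scatter).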

Compound 3, dose for half-maximal effect: 19 mg/kg
Beside the measured number, compound 3's estimate is 1.1-fold (0.02 log units) below it, within the range that was stated.
By their numbers in this assay, from the lowest: compounds 2, 3 and 1 (each within the scatter of the next, the first and the last beyond it).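

Phenyl in place of butyl on a saturated chain carbon bound to an aromatic carbon gives a 1.7-fold lower number from compound 1 to compound 3 (0.24 log units; within the scatter) in this assay and so cannot be told apart from the scatter at this position. Benzyl in place of 4-methylphenyl gives a 1.7-fold higher number from compound 2 to compound 3 (0.22 log units; within the scatter) and is equally unresolved, which leaves the benzyl compound within the scatter of both others, while only a 2.9-fold lower number from compound 1 to compound 2 (0.46 log units; beyond the scatter) separates the two ends of the series. No supporting data bear on why these groups compare as they do.

Still open, on these data alone, is whether a phenylethyl group or a longer chain on this carbon would carry the number beyond the scatter. Also open, as far as these compounds go, is what a ring bearing an amine or a carboxylic acid would do in place of 4-methylphenyl.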